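Shortening the Ester Arm of a Dimethylaminomethyl Analogue

The source may hold more compounds than are shown below. What is called first, only, known or untested is meant among the compounds shown, and "the series" means these compounds.

Compound 1, `O=C(/C=C/c1ccc(F)cc1)Oc1ccc(/C=C2\CCCCC2=O)cc1`: 26600 nM
Compound 2, `O=C(/C=C/c1ccc(Cl)c(Cl)c1)Oc1ccc(/C=C2\CCCCC2=O)cc1`: 47300 nM
Compound 3, `CN(C)CC1CCC/C(=C\c2ccc(OC(=O)/C=C/c3ccc(F)cc3)cc2)C1=O`: 3780 nM

In a functional assay on MOLT-4 cells (Homo sapiens) (a higher number here means a weaker inhibitor, a lower number a stronger inhibitor), compound 3 stands lowest of the three: a 7.0-fold lower number from compound 1 to compound 3 (0.85 log units; beyond the scatter) sets it apart from compound 1, and compound 2 lies further away still. Compound 4, `CN(C)CC1CCC/C(=C\c2ccc(OC(=O)c3ccc(Cl)cc3)cc2)C1=O`, keeps the core of compound 3 and alters the ester: 4-chlorophenyl in place of 2-(4-fluorophenyl)ethenyl on a carbonyl carbon. Within the data shown here, only one measured step touches this end of the molecule, a 1.8-fold higher number from compound 1 to compound 2 (0.25 log units; within the scatter), and that change stayed within the scatter. Among the measured compounds shown here, no measured pair removes the ethenyl link, so that part of the change is untested. The step of a 1.5-fold higher number from compound 3 to compound 4 (0.16 log units; within the scatter) is therefore expected to be small, with a somewhat higher number a little more likely than a lower one. Compound 4 is estimated at 5500 nM, within 1800 nM to 16000 nM.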

Compound 4, half-maximal inhibitory concentration: 5110 nM
Beside the measured number, compound 4's estimate is 1.1-fold (0.03 log units) above it; low and high end bracket the measured number.
By their numbers in this assay, from the lowest: compounds 3 and 4 (each within the scatter of the next); then compounds 1 and 2 (each within the scatter of the next).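

In this assay, among these compounds, 4-chlorophenyl in place of 2-(4-fluorophenyl)ethenyl on the carbonyl carbon gives a 1.4-fold higher number from compound 3 to compound 4 (0.13 log units; within the scatter) and so shows something no earlier pair could: with the (dimethylamino)methyl group present, this end of the ester can lose its double bond outside the aromatic rings and stay within the scatter. No measurement at hand explains this result.

On these data alone, the step changes the link and the ring halogen together, so their separate contributions remain unknown. A longer chain, or a phenyl ring bearing an amine, at this carbonyl carbon also remains an open question.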